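Aryl swap on the acyl urea of compound 3

The source may report more compounds than this note shows. Statements on the series, on what has been measured and on what is new or still open speak of the compounds shown alone.

Compound 1 `CN(C(=O)NC(=O)c1ccc([N+](=O)[O-])cc1)c1nc(C(F)(F)F)c(C(=O)N/N=C/c2cccc(C(F)(F)F)c2)s1` gives 4.12 ug/mL in a functional assay on HeLa cells (Homo sapiens) for inhibition, read by MTT assay, with a stated time of 72 h; a lower number here means a stronger inhibitor, a higher number a weaker inhibitor.
Compound 2 `CN(C(=O)NC(=O)c1ccc(F)c(F)c1)c1nc(C(F)(F)F)c(C(=O)N/N=C/c2ccc([N+](=O)[O-])cc2)s1` gives 5.08 ug/mL.
Compound 3 `CN(C(=O)NC(=O)c1ccc(F)c(F)c1)c1nc(C(F)(F)F)c(C(=O)N/N=C/c2cccc(C(F)(F)F)c2)s1` gives 4.21 ug/mL.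

Compound 3 stands second highest of these three numbers in this assay, nearest to compound 1 and furthest from compound 2, with both gaps within the scatter. Compound 4 `CN(C(=O)NC(=O)c1ccc(Cl)cc1Cl)c1nc(C(F)(F)F)c(C(=O)N/N=C/c2cccc(C(F)(F)F)c2)s1` differs from compound 3 in one place: 2,4-dichlorophenyl in place of 3,4-difluorophenyl on a carbonyl carbon. For the measured compounds named here, the only step at this same carbonyl carbon is a 1.0-fold higher number from compound 1 to compound 3 (0.01 log units; within the scatter), which left the number unchanged. The other step, a 1.2-fold lower number from compound 2 to compound 3 (0.08 log units; within the scatter), concerns a different part of the shared core and was also small. Compound 4 is therefore expected to show no step beyond the scatter, a 1.1-fold higher number from compound 3 to compound 4 (0.03 log units; within the scatter). The value of compound 4 in this assay is estimated at 4.5 ug/mL, in a range from 2.3 ug/mL to 9 ug/mL.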

Compound 4, half-maximal inhibitory concentration: 9.6 ug/mL
Compound 4: middle estimate off by 2.1-fold (0.33 log units), on the low side; measured number above the stated range.
By their numbers in this assay, from the lowest: compounds 1, 3, 2 and 4 (each within the scatter of the next, the first and the last beyond it).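

At this carbonyl carbon, 2,4-dichlorophenyl brings a 2.3-fold higher number from compound 3 to compound 4 (0.36 log units; beyond the scatter) and a 2.3-fold higher number from compound 1 to compound 4 (0.37 log units; beyond the scatter) in this assay whereas the earlier exchange of 4-nitrophenyl for 3,4-difluorophenyl stayed within the scatter. The position therefore does respond to its aryl group, although the step is modest and this single change alters both the halogen and its placement on the ring. Nothing measured here accounts for the step.

As far as these compounds go, whether the halogen or its placement matters remains open, as does how 4-chlorophenyl or 3,4-dichlorophenyl would read at this carbonyl carbon. Also open, from the compounds shown here alone, is whether 2,4-dichlorophenyl gives a similar step with 4-nitrophenyl on the carbon with a double bond to nitrogen.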